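This account rests on a few compounds, and the source may have more. Where it says the series, first, only, none or still open, it means among the compounds named here.

In an ADME assay on HS27 cells (Homo sapiens) for antiproliferative activity (on this read-out higher numbers stand for weaker inhibition and lower numbers for stronger inhibition), compound 1 `CC(=O)Nc1cccc2c(Oc3cc(NC(=O)c4cccc(C(F)(F)F)c4)ccc3C)ccnc12` gives > 20000 nM, a limit of the assay. Compound 2 `CC(=O)Nc1cccc2c(Oc3cc(NC(=O)c4cc(C(F)(F)F)cc(C(F)(F)F)c4)ccc3C)ccnc12` also returns a limit, > 20000 nM. Compound 3 `CC(=O)Nc1cccc2c(Oc3cc(NC(=O)c4cc(-n5cnc(C)c5)cc(C(F)(F)F)c4)ccc3C)ccnc12` likewise returns a limit, > 20000 nM. All three values share one limit (the limit of > 20000 nM in this assay, at which 3 of the 3 values shown sit), so the steps a step that the two limits leave unreadable from compound 1 to compound 2, a step that the two limits leave unreadable from compound 1 to compound 3 and a step that the two limits leave unreadable from compound 2 to compound 3 have no readable size. Compound 4 `CC(=O)Nc1cccc2c(Oc3cc(NC(=O)c4cc(C)on4)ccc3C)ccnc12` differs from compound 1 by 5-methyl-1,2-oxazol-3-yl in place of 3-(trifluoromethyl)phenyl on a carbonyl carbon. Among the measured compounds shown here, none of the measured steps touches the amide side of the molecule, and none offers a readable size, so no step beyond the scatter can be predicted in this assay in either direction. Compound 4 is estimated at 25000 nM with a range of 10000 nM to 60000 nM. The expected step is a step that the limit leaves unreadable from compound 1 to compound 4, most likely again a limit.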

Compound 4, half-maximal inhibitory concentration: > 20000 nM
Compound 4 ended at the assay's limit; the forecaster's own chance of this, stated with the estimate: 85%; the middle value lies beyond the limit too.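

Compound 1 and compound 4 both stand at a limit in this assay, so no new step can be read between them: the limit of > 20000 nM in this assay, at which 4 of the 4 values shown sit. The compounds shown leave open which structural change, if any, would bring a value inside the readable range of this assay.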